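This account rests on a few compounds, and the source may have more. Where it says the series, first, only, none or still open, it means among the compounds named here.

Compound 1 `CCn1c(N[C@H]2CC[C@H](C(=O)OC)CC2)nc2ccsc2c1=O` gives 2100 nM in an assay on cells for inhibition of high affinity 3',5'-cyclic-AMP phosphodiesterase 7A (Homo sapiens), read by scintillation counting and cAMP accumulation, with a stated time of 30 min; a lower number here means a stronger inhibitor, a higher number a weaker inhibitor.
Compound 2 `CCn1c(N[C@H]2CC[C@H](C(=O)O)CC2)nc2ccsc2c1=O` gives 1300 nM in this assay.

Of these two numbers compound 2 has the lower one, yet a 1.6-fold lower number from compound 1 to compound 2 (0.21 log units; within the scatter), so the two compounds cannot be told apart. Compound 3 `CCn1c(N[C@H]2CC[C@H](O)CC2)nc2ccsc2c1=O` differs from compound 2 by hydroxy in place of carboxy on a saturated ring carbon. Going by the values given here, the only step known, a 1.6-fold lower number from compound 1 to compound 2 (0.21 log units; within the scatter), also altered the group on that saturated ring carbon and stayed within the scatter. Going from carboxy to hydroxy is a larger alteration, so the expectation is uncertain, but no step beyond the scatter is expected in this assay. Compound 3 is therefore estimated at 1800 nM, within 600 nM to 5500 nM, meaning an expected step of a 1.4-fold higher number from compound 2 to compound 3 (0.14 log units; within the scatter).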

Compound 3, half-maximal inhibitory concentration in the high affinity 3',5'-cyclic-AMP phosphodiesterase 7A assay: 2300 nM
Beside the measured number, compound 3's estimate is 1.3-fold (0.11 log units) below it; low and high end bracket the measured number.
By their numbers in the high affinity 3',5'-cyclic-AMP phosphodiesterase 7A assay, from the lowest: compounds 2, 1 and 3 (each within the scatter of the next).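

In the high affinity 3',5'-cyclic-AMP phosphodiesterase 7A assay, swapping the group on this saturated ring carbon for the smaller hydroxy gives a 1.8-fold higher number from compound 2 to compound 3 (0.25 log units; within the scatter) and a 1.1-fold higher number from compound 1 to compound 3 (0.04 log units; within the scatter), so carboxy, methoxycarbonyl and hydroxy cannot be told apart there. The same change from carboxy to hydroxy does register in a different measurement, a physicochemical assay for solubility, in phosphate buffer, at pH 6.8 (a higher number here means a more soluble compound, a lower number a less soluble compound), where compound 2 gives 450 ug/mL and compound 3 gives 74 ug/mL and solubility falls beyond the scatter: the measured solubility of compound 2, 450 ug/mL, and of compound 3, 74 ug/mL, a 6.1-fold lower number (0.78 log units; beyond the scatter)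

Open, going by these compounds, is whether an amine or a longer chain on this ring carbon would give a step beyond the scatter in the high affinity 3',5'-cyclic-AMP phosphodiesterase 7A assay, and in which direction.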